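The compounds below may be only part of what the source reports. "The series", "measured", "known", "first", "only" and "open" are said of these compounds alone.

Compound 1, `COc1ccc(OC)c(/C=N/NC(=O)c2cc(OC)c(OC)c(OC)c2)c1`, and compound 2, `COc1ccc(C2OC(c3cc(OC)c(OC)c(OC)c3)=NN2C(C)=O)c(OC)c1`, were both examined in a functional assay on BGC-823 cells (Homo sapiens) for antiproliferative activity, read by MTT assay, tested at 5 uM; a higher number here means a stronger effect of the compound at the concentration tested, a lower number a weaker effect. In that assay compound 1 gives 10.1%, while compound 2 gives -3.1%. Compound 2 therefore stands lowest of the two numbers, and compound 1 sits higher by an amount beyond the usual scatter. Compound 3, `COc1cc(C2=NN(C(C)=O)C(c3ccc(F)c(F)c3)O2)cc(OC)c1OC`, has not yet been tested in this assay. It differs from compound 2 in one place: 3,4-difluorophenyl in place of 2,4-dimethoxyphenyl on a saturated ring carbon. The group that leaves carries two hydrogen-bond acceptors, the group that enters carries none, and both sit on the saturated ring carbon next to the ring oxygen. Going by the values given here, no pair of measured compounds here differs by this single exchange, so there is nothing to show its usual size. A step no larger than the scatter is expected, a number 7.1 percentage points higher from compound 2 to compound 3 (within the scatter), in either direction. Compound 3 is thus estimated at 4%, with a range from -12% to 22%.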

Compound 3, a percentage reported as inhibition, at one concentration (the size of the read-out at that concentration, not a potency): 21.6%
Estimate against measurement, compound 3: 17.6 percentage points below; the range from low to high includes it.
By their numbers in this assay, from the lowest: compound 2; then compound 1; then compound 3.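

Compound 3's result shows that the aryl group on the saturated ring carbon next to the ring oxygen is not a silent part of the structure: in this assay, 3,4-difluorophenyl in place of 2,4-dimethoxyphenyl brings a number 24.7 percentage points higher from compound 2 to compound 3 (beyond the scatter), a step the earlier pair could not reveal because it differed in more than one place. The effect at this concentration can therefore change with this group alone, while the rest of the core stays the same. Nothing measured here accounts for the step.

The exchange removes the methoxy groups and introduces the fluorines together, so the compounds shown leave open which of these changes carries the step. Also open, from the compounds shown here alone, is how this position would respond to an unsubstituted phenyl, a monofluorophenyl or a phenyl bearing an amine or a carboxylic acid.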